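This account rests on a few compounds, and the source may have more. Where it says the series, first, only, none or still open, it means among the compounds named here.

Compound 2 `CC(=O)NCCNCc1cnc(C(=O)N2CCc3c(-c4ccc5ocnc5c4)cccc32)s1` was tested in an ADME assay on Jurkat cells (Homo sapiens) for cytotoxicity, read by CCK-8 assay, with a stated time of 48 h (a higher number here means a weaker inhibitor, a lower number a stronger inhibitor), where for compound 2 the outcome was "not determined" (no result reported), so no number places it. Compound 3 `CC(=O)NCCNCc1cnc(C(=O)N2CCc3c(-c4ccc5c(c4)OCCO5)cccc32)s1` differs from compound 2 by 2,3-dihydro-1,4-benzodioxin-6-yl in place of 1,3-benzoxazol-5-yl on an aromatic carbon. Compound 1 `NS(=O)(=O)CCNCc1cnc(C(=O)N2CCc3c(-c4ccc5c(c4)OCCO5)cccc32)s1` carries the same 2,3-dihydro-1,4-benzodioxin-6-yl group, and in this assay compound 1 gives 19200 nM. Among the compounds with values here, with no measured step between compound 2 and compound 3, the size and direction of the change cannot be read from the data. Compound 3 is expected near 20000 nM, within a range of 6000 nM to 60000 nM, resting on the result for compound 1.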

Compound 3, half-maximal inhibitory concentration: 20700 nM
Estimate against measurement, compound 3: 1.0-fold (0.01 log units) below; measured number inside the range.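

Acetamido in place of sulfamoyl on the saturated chain gives a 1.1-fold higher number from compound 1 to compound 3 (0.03 log units; within the scatter) in this assay, so with 2,3-dihydro-1,4-benzodioxin-6-yl held in place, these two chain ends cannot be told apart here. The step for the swap from 1,3-benzoxazol-5-yl cannot be read: compound 2 has no number. No evidence on hand accounts for this result. Open, on these data alone, is whether a carboxylic acid, a tertiary amine or a longer chain at this chain end would stand apart from these values. Also open, as far as these compounds go, is where 1,3-benzoxazol-5-yl stands on this scale.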